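The source may report more compounds than this note shows. Statements on the series, on what has been measured and on what is new or still open speak of the compounds shown alone.

Compound 3 `CCCSc1nnc(Cc2ccccc2Oc2ccccc2)[nH]1` is one of three compounds that share a core and differ only in the group carried on a saturated chain carbon bound to a sulfur. In a functional assay on the whole organism (strain NMRI) with Mus musculus as the target, with a stated time of 60 min, at a dose of 5 mg/kg by the intraperitoneal route (a higher number here means a stronger effect of the compound at the dose given, a lower number a weaker effect), compound 3 gives 128%, which is the second highest of the three numbers: compound 2 `CCSc1nnc(Cc2ccccc2Oc2ccccc2)[nH]1` gives 132% and compound 1 `CSc1nnc(Cc2ccccc2Oc2ccccc2)[nH]1` gives 120%, and both of these lie within the scatter of the value of compound 3. For the measured compounds named here, the step of a number 12 percentage points higher from compound 1 to compound 2 (beyond the scatter) is the only change at this place that goes beyond the scatter; the step of a number 8 percentage points higher from compound 1 to compound 3 (within the scatter) and the step of a number 4 percentage points lower from compound 2 to compound 3 (within the scatter) do not. Compound 4 `c1ccc(CSc2nnc(Cc3ccccc3Oc3ccccc3)[nH]2)cc1` is not yet measured. It differs from compound 3 in that (phenyl in place of ethyl on a saturated chain carbon bound to a sulfur). The measured steps that bear on it are those that enlarged the group at this place, and their effect was modest or within the scatter. Compound 4 is therefore expected to give 130%, within a range from 105% to 155%, a step of a number 2 percentage points higher from compound 3 to compound 4 (within the scatter) that is estimated to stay within the scatter.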

Compound 4, a percentage reported as activity, at one dose (the size of the read-out at that dose, not a potency): 129%
Compound 4: middle estimate off by 1 percentage points, on the high side, and the stated range covers the measured number.
By their numbers in this assay, from the lowest: compounds 1, 3, 4 and 2 (each within the scatter of the next, the first and the last beyond it).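

Up to this point the groups on a saturated chain carbon bound to a sulfur were small open chains. Compound 4 shows that phenyl, with its six-membered aromatic ring, also keeps the read-out in this assay at the level of those compounds, with a number 1 percentage points higher from compound 3 to compound 4 (within the scatter), a number 3 percentage points lower from compound 2 to compound 4 (within the scatter) and a number 9 percentage points higher from compound 1 to compound 4 (within the scatter). For the compounds shown here, the one step at this place beyond the scatter therefore remains a number 12 percentage points higher from compound 1 to compound 2 (beyond the scatter), so a larger group did not by itself separate a compound from compound 1, and no information is available on why these compounds fall so close together.

From the compounds shown here alone, it remains open whether a longer chain such as hexyl, or a phenyl carrying an amine or a carboxylic acid, would move the number beyond the scatter. Since each compound is seen at a single dose, these numbers also leave open whether compounds 1 to 4 would differ in a stronger or weaker effect at any other dose.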